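The compounds below may be only part of what the source reports. "The series", "measured", "known", "first", "only" and "open" are said of these compounds alone.

Of the compounds shown here, three have so far been measured in a functional assay on SN12C cells (Homo sapiens) for inhibition, read by sulforhodamine B assay, with a stated time of 48 h, tested at 10 uM; on this read-out lower numbers stand for less inhibition and higher numbers for more inhibition at the one concentration tested (going by the name of the read-out). Compound 1 `c1ccc2c(-c3cn4ccnc4c(-c4ccc5ncn(C6CCCCC6)c5c4)n3)cccc2c1` gives 11.7% in this assay. Compound 2 `CCc1ccc(-c2cn3ccnc3c(-c3ccc4ncn(Cc5ccccc5)c4c3)n2)cc1` gives 22.5%, and compound 3 `O=Cc1ccc(-c2cn3ccnc3c(-c3ccc4ncn(Cc5ccccc5)c4c3)n2)cc1` gives 20.7%. Going by the values given here, compound 3 thus stands second highest of the three numbers; its nearest neighbour is compound 2, and the single measured step, a number 1.8 percentage points lower from compound 2 to compound 3 (within the scatter), lies within the scatter, as does the gap between compound 3 and compound 1.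

The next compound, compound 4 `c1ccc(Cn2cnc3ccc(-c4nc(-c5cccc6ccccc56)cn5ccnc45)cc32)cc1`, differs from compound 3 in one place: naphthalen-1-yl in place of 4-formylphenyl on an aromatic carbon. Among the compounds with values here, no measured step covers an exchange of one whole aromatic group for another; the only step available, a number 1.8 percentage points lower from compound 2 to compound 3 (within the scatter), concerns a small change within the 4-formylphenyl group and stayed within the scatter, so it says little about the present change. Compound 1 also carries naphthalen-1-yl and gives 11.7%, but it differs from compound 4 in a second place as well, so it serves only as a loose pointer toward the lower end of the measured numbers.

Weighing this, the step is expected to be a number 6.7 percentage points lower from compound 3 to compound 4 (within the scatter), a modest move downward that may well stay within the scatter. Compound 4 is therefore estimated at 14%, with a range from 4% to 26%.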

Compound 4, a percentage reported as inhibition, at one concentration (the size of the read-out at that concentration, not a potency): 5.62%
Estimate against measurement, compound 4: 8.4 percentage points above; the measured number falls inside the stated range.
By their numbers in this assay, from the lowest: compounds 4, 1, 3 and 2 (each within the scatter of the next, the first and the last beyond it).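

In this assay the carbon bearing the aryl group now shows a change that can be read: naphthalen-1-yl in place of 4-formylphenyl gives a number 15.1 percentage points lower from compound 3 to compound 4 (beyond the scatter) and naphthalen-1-yl in place of 4-ethylphenyl gives a number 16.9 percentage points lower from compound 2 to compound 4 (beyond the scatter) while the change between the two substituted phenyl groups themselves, a number 1.8 percentage points lower from compound 2 to compound 3 (within the scatter) did not separate them. With naphthalen-1-yl held in place, benzyl in place of cyclohexyl on the aromatic nitrogen gives a number 6.1 percentage points lower from compound 1 to compound 4 (within the scatter) so the change at the nitrogen shows no difference that can be told from the scatter, whereas the exchange of the whole aromatic group at the carbon does. Nothing among the data available explains why naphthalen-1-yl stands apart from the two substituted phenyl groups.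

On these data alone, it remains open whether a phenyl group carrying an amine or a carboxylic acid in the same place would stay with compound 2 and compound 3 or fall with compound 4. Also open, as far as these compounds go, is whether a longer chain on the aromatic nitrogen would change the picture, and whether the effect of the aromatic group at the carbon holds with cyclohexyl on that nitrogen.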